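Ester to Anilide on a Cinnamate Sulfonate Scaffold

The compounds below may be only part of what the source reports. "The series", "measured", "known", "first", "only" and "open" are said of these compounds alone.

Measured compounds:
compound 1, `CCCOC(=O)/C=C/c1ccc(OS(=O)(=O)c2ccc(Cl)cc2)c(OC)c1`: 150000 nM
compound 2, `CCCCOC(=O)/C=C/c1ccc(OS(=O)(=O)c2ccc(Cl)cc2)c(OC)c1`: 14000 nM

The two measured compounds share a common core and differ only in the chain on the ester oxygen. In a toxicity assay on L02 cells (Homo sapiens) for cytotoxicity, read by MTT assay, with a stated time of 24 h (a higher number here means that more compound is tolerated, a lower number that less compound is tolerated), compound 1 gives 150000 nM and compound 2 gives 14000 nM. Among the compounds with values here, the single measured step, an 11-fold lower number from compound 1 to compound 2 (1.03 log units; beyond the scatter), lengthens the chain by one carbon and leaves compound 2 with the lowest of the two numbers, so less of compound 2 is tolerated than of compound 1.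

Compound 3, `COc1cc(/C=C/C(=O)Nc2cccc(C)c2)ccc1OS(=O)(=O)c1ccc(Cl)cc1`, is not yet measured. It differs from compound 2 by (3-methylphenyl)amino in place of butoxy on a carbonyl carbon. This change is of another kind than the measured step: the ester oxygen and its chain leave altogether and an aromatic amide takes their place. The step from compound 1 to compound 2 therefore bears on it only loosely; it shows that a small change at this end of the molecule can move the number well beyond the scatter, but not in which direction an anilide would move it. Compound 3 is expected to sit near compound 2, estimated at 10000 nM (range 2500 nM to 40000 nM), an expected step of a 1.4-fold lower number from compound 2 to compound 3 (0.15 log units; within the scatter).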

Compound 3, half-maximal cytotoxic concentration: 73500 nM
The estimate for compound 3 lay 7.4-fold (0.87 log units) below the measured number; the whole stated range lies below it.
By their numbers in this assay, from the lowest: compound 2; then compound 3; then compound 1.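

In this assay the anilide gives two steps that point in opposite directions: (3-methylphenyl)amino in place of butoxy on the carbonyl carbon is a 5.3-fold higher number from compound 2 to compound 3 (0.72 log units; beyond the scatter) and in place of propoxy is a 2.0-fold lower number from compound 1 to compound 3 (0.31 log units; beyond the scatter) on the same scale. The earlier compounds shown here showed only that this end of the molecule responds to one added carbon in the ester chain; these steps show that the ester oxygen and its chain can be replaced outright by an aromatic amide, and that the number then falls between those of the two esters, with both steps beyond the scatter. No measurement available here explains why the anilide falls at this point.

The compounds shown do not separate the part played by the amide nitrogen from that of the ring, so butylamino or unsubstituted phenylamino on the same carbonyl carbon would be the comparisons that could divide the step. They also leave open whether the methyl on the ring contributes anything, and whether a longer chain such as pentoxy would continue the change seen between the two esters.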